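Enone amides on the ring nitrogen of the shared core

The compounds below may be only part of what the source reports. "The series", "measured", "known", "first", "only" and "open" are said of these compounds alone.

Measured so far:
compound 1 `CC(=O)N1C[C@H]2CC[C@H](O[C@H](C)c3cc(C(F)(F)F)cc(C(F)(F)F)c3)[C@@H](c3ccc(F)cc3)[C@@H]2C1` in an assay on CHO cells for displacement of a labelled ligand from Substance-P receptor (Homo sapiens), in the absence of a further agent (a higher number here means a weaker inhibitor, a lower number a stronger inhibitor), gives 0.11 nM
compound 2 `CC1=C(N2C[C@H]3CC[C@H](O[C@H](C)c4cc(C(F)(F)F)cc(C(F)(F)F)c4)[C@@H](c4ccc(F)cc4)[C@@H]3C2)CCC1=O` in this assay gives 0.1 nM

Compound 2 has the lower of the two numbers, with compound 1 within the scatter of it; the step of a 1.1-fold lower number from compound 1 to compound 2 (0.04 log units; within the scatter) is the only one measured. Compound 3 `C[C@@H](O[C@H]1CC[C@@H]2CN(C3=CC(=O)CCC3)C[C@H]2[C@@H]1c1ccc(F)cc1)c1cc(C(F)(F)F)cc(C(F)(F)F)c1` differs from compound 2 by 3-oxocyclohex-1-en-1-yl in place of 2-methyl-3-oxocyclopent-1-en-1-yl on an amine nitrogen in a ring. Among the measured compounds shown here, the one measured change at this nitrogen left the number unmoved, so no step beyond the scatter is expected here either; the estimated step is a 1.2-fold higher number from compound 2 to compound 3 (0.08 log units; within the scatter). Compound 3 is expected to give 0.12 nM, in the range 0.05 nM to 0.3 nM.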

Compound 3, half-maximal inhibitory concentration: 0.13 nM
Compound 3: the middle estimate sits 1.1-fold (0.03 log units) below what was measured; measured number inside the range.
By their numbers in this assay, from the lowest: compounds 2, 1 and 3 (each within the scatter of the next).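

In this assay the swap to 3-oxocyclohex-1-en-1-yl gives a 1.3-fold higher number from compound 2 to compound 3 (0.11 log units; within the scatter) and, set against acetyl, a 1.2-fold higher number from compound 1 to compound 3 (0.07 log units; within the scatter). On this amine nitrogen in a ring, a six-membered ring without the methyl therefore reads the same as the five-membered methylated ring and as acetyl. Nothing available gives a reason for this. Ring size and the methyl changed together, so their separate contributions remain unresolved. As far as these compounds go, whether a basic amine or a carboxylic acid on this nitrogen would keep the number also stays open.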